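The source may report more compounds than this note shows. Statements on the series, on what has been measured and on what is new or still open speak of the compounds shown alone.

Measured so far:
compound 1, `CCCCS(=O)(=O)n1ccc2ccc(-c3ccncc3)cc21` — 1150 nM
compound 2, `O=S(=O)(N1CCCCC1)n1ccc2ccc(-c3ccncc3)cc21` — 1660 nM

In an assay on isolated protein for displacement of a labelled ligand from 5-hydroxytryptamine receptor 6 (Homo sapiens), read by scintillation counting, with a stated time of 1 h (on this read-out lower numbers stand for stronger inhibition and higher numbers for weaker inhibition), compound 2 gives 1660 nM, the highest of the two numbers, with compound 1 nearest at 1150 nM; the step of a 1.4-fold higher number from compound 1 to compound 2 (0.16 log units; within the scatter) lies within the scatter, so the two compounds cannot be ordered. Compound 3, `O=S(=O)(C1CCCCC1)n1ccc2ccc(-c3ccncc3)cc21`, has not yet been measured. It differs from compound 2 by cyclohexyl in place of piperidin-1-yl on a sulfonyl sulfur. Among the compounds with values here, the only measured step that bears on this place is the one from compound 1 to compound 2, a 1.4-fold higher number from compound 1 to compound 2 (0.16 log units; within the scatter), where a change at the same sulfonyl sulfur left the number within the scatter. Nothing measured points to a shift beyond the scatter in this assay, so compound 3 is expected to land near compound 2 and compound 1, with the step of a 1.3-fold lower number from compound 2 to compound 3 (0.11 log units; within the scatter) as the expectation. The estimate for compound 3 is 1300 nM, with a range from 500 nM to 3500 nM.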

Compound 3, inhibition constant: 2180 nM
Compound 3: middle estimate off by 1.7-fold (0.22 log units), on the low side; low and high end bracket the measured number.
By their numbers in this assay, from the lowest: compounds 1, 2 and 3 (each within the scatter of the next).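

In this assay, cyclohexyl in place of piperidin-1-yl on a sulfonyl sulfur gives a 1.3-fold higher number from compound 2 to compound 3 (0.12 log units; within the scatter) even though a ring nitrogen gives way to carbon, so this assay does not separate the two rings. Cyclohexyl in place of butyl gives a 1.9-fold higher number from compound 1 to compound 3 (0.28 log units; within the scatter) and thus also stays inside the scatter, which means that butyl, piperidin-1-yl and cyclohexyl at this position cannot be ordered. No independent data bear on why these three groups are not separated.

The compounds shown leave open whether a phenyl ring, or a chain ending in an amine, on the sulfonyl sulfur would move the number beyond the scatter. They also say nothing about changes to the shared core, which all three compounds carry unaltered.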